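Swapping the Hydrazone Aryl Group: Pyrazole to Pyridine

The compounds below may be only part of what the source reports. "The series", "measured", "known", "first", "only" and "open" are said of these compounds alone.

Compound 1 `NS(=O)(=O)c1ccc(Nc2nc(N/N=C/c3ccc(C(F)(F)F)cc3)nc(Nc3ccccc3)n2)cc1`: 50100 nM
Compound 2 `Cc1nn(-c2ccccc2)cc1/C=N/Nc1nc(Nc2ccccc2)nc(Nc2ccc(S(N)(=O)=O)cc2)n1`: > 100000 nM

In a functional assay on HT-29 cells (Homo sapiens) for inhibition, read by sulforhodamine B assay, with a stated time of 48 h (a higher number here means that more compound is tolerated, a lower number that less compound is tolerated), compound 1 gives 50100 nM. In this assay compound 2 gives > 100000 nM, which is a limit of the assay and not a number, so compound 2 stands only as a value at or beyond that edge (the limit of > 100000 nM in this assay, at which 1 of the 2 values shown sits). Among the measured compounds shown here, the one measured step between them, an at least 1.9-fold higher number from compound 1 to compound 2 (0.30 log units; that floor lies within the scatter), is a floor that lies within the usual scatter, so the two compounds cannot be ordered with confidence.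

Compound 3 `NS(=O)(=O)c1ccc(Nc2nc(N/N=C/c3ccccn3)nc(Nc3ccccc3)n2)cc1` has not been tested. It differs from compound 2 in one place: pyridin-2-yl in place of 3-methyl-1-phenyl-1H-pyrazol-4-yl on a carbon with a double bond to nitrogen. The measured step bears on it only loosely, since the pyridin-2-yl group of compound 3 is a different aryl group from both the 4-(trifluoromethyl)phenyl of compound 1 and the pyrazolyl of compound 2. With no change beyond the scatter seen so far, no step beyond the scatter is expected here either. Compound 3 is therefore estimated at 70000 nM, with a range from 25000 nM to 200000 nM. The expected step is an at least 1.4-fold lower number from compound 2 to compound 3 (0.15 log units; that floor lies within the scatter).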

Compound 3, concentration lethal to 50% of the cells: > 100000 nM
Compound 3 was reported as a limit; the forecaster's own chance of this, stated with the estimate: 45%; at least 1.4-fold (0.15 log units) between middle value and limit.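

In this assay compound 3 gives > 100000 nM, which is a limit of the assay and not a number. Among the compounds shown here, what is new is that this carbon has now carried both the 12 heavy atoms of 3-methyl-1-phenyl-1H-pyrazol-4-yl and the 6 heavy atoms of pyridin-2-yl, and both compounds end at the same edge, so the step between them cannot be read because neither value is a number: the limit of > 100000 nM in this assay, at which 2 of the 3 values shown sit. The only step that can be read for the new compound, an at least 1.9-fold higher number from compound 1 to compound 3 (0.30 log units; that floor lies within the scatter), is a floor that lies within the usual scatter, so the change from 4-(trifluoromethyl)phenyl to pyridin-2-yl gives the two compounds no order.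

The true size of any difference among these three compounds remains hidden, as two of the values are limits and the floors do not rise beyond the scatter. From the compounds shown here alone, whether a phenyl ring carrying an amine or a carboxylic acid on this carbon would give a result clearly apart from compound 1, which gives 50100 nM, also remains open.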